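The source may report more compounds than this note shows. Statements on the series, on what has been measured and on what is new or still open speak of the compounds shown alone.

Measured compounds in an in vitro functional assay on 1321-N1 cells for agonist activity at Free fatty acid receptor 1 (Homo sapiens), read by fluorescence, spectrophotometry and calcium flux; a lower number here means that less compound is needed, a higher number that more compound is needed for the effect:
compound 1, `O=C(O)CCc1ccc(C#Cc2ccnc(F)c2)cc1`: 513 nM
compound 2, `O=C(O)CCc1ccc(C#Cc2ccnc(Cl)c2)cc1`: 295 nM
compound 3, `O=C(O)CCc1ccc(C#Cc2ccccn2)cc1`: 13200 nM

Compound 3 gives the highest number of the three in this assay: compound 1 lies a long way lower, beyond the scatter, and compound 2 lies further lower still. Between compound 1 and compound 2 the only measured single step, a 1.7-fold lower number from compound 1 to compound 2 (0.24 log units; within the scatter), is a swap of halogens that changes little.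

Compound 4, `O=C(O)CCc1ccc(C#Cc2ccncc2)cc1`, is not yet measured. It differs from compound 3 in one place: pyridin-4-yl in place of pyridin-2-yl on a triple-bonded carbon. Going by the values given here, no measured step covers this exact change, so it has to be judged from the values alone. Compound 1 and compound 2 both carry a pyridin-4-yl ring bearing a halogen, and both give much lower numbers in this assay than compound 3 with its pyridin-2-yl ring. Compound 4 carries the bare pyridin-4-yl ring and lacks the halogen, so the step is expected to go in the same direction but not to reach as far.

Compound 4 is therefore expected to give about 1500 nM in this assay, with a likely range from 400 nM to 6000 nM; this expectation corresponds to a step of an 8.8-fold lower number from compound 3 to compound 4 (0.94 log units; beyond the scatter).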

Compound 4, half-maximal effective concentration: 4070 nM
Compound 4: the middle estimate sits 2.7-fold (0.43 log units) below what was measured; the range from low to high includes it.
By their numbers in this assay, from the lowest: compounds 2 and 1 (each within the scatter of the next); then compound 4; then compound 3.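

In this assay, going by these compounds alone, the earlier compounds showed the pyridin-4-yl ring only with a halogen on it, so the effect of the ring could not be told apart from the effect of the halogen. Compound 4 separates the two: with the same atoms joined differently, pyridin-4-yl in place of pyridin-2-yl on the triple-bonded carbon gives a 3.2-fold lower number from compound 3 to compound 4 (0.51 log units; beyond the scatter), a real but modest change. Taking the halogen away then counts for more, with hydrogen in place of chloro giving a 14-fold higher number from compound 2 to compound 4 (1.14 log units; beyond the scatter) and hydrogen in place of fluoro giving a 7.9-fold higher number from compound 1 to compound 4 (0.90 log units; beyond the scatter), so on this ring either halogen is clearly better than hydrogen, and nothing available here explains why either change acts as it does.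

The compounds shown leave open whether a bromo or a methoxy group on that aromatic carbon would serve as the two halogens do, and where a pyridin-3-yl or plain phenyl ring would stand on the triple-bonded carbon. They also leave open whether a chloro group would bring a similar step on the pyridin-2-yl ring of compound 3.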